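The source may report more compounds than this note shows. Statements on the series, on what has been measured and on what is new or still open speak of the compounds shown alone.

Measured compounds:
Compound 1 `CC(C(=O)NCc1ccc(C(F)(F)F)nc1CCC(C)(C)C)c1ccc(NS(C)(=O)=O)c(F)c1` gives 0.6 nM in an assay on CHO cells for antagonist activity at transient receptor potential cation channel subfamily V member 1 (Homo sapiens), read by FLIPR and calcium flux; on this read-out higher numbers stand for weaker inhibition and lower numbers for stronger inhibition.
Compound 2 `CCC1CCC(c2nc(C(F)(F)F)ccc2CNC(=O)C(C)c2ccc(NS(C)(=O)=O)c(F)c2)CC1` gives 0.3 nM in this assay.
Compound 3 `CC(C(=O)NCc1ccc(C(F)(F)F)nc1C1CC2CCC1C2)c1ccc(NS(C)(=O)=O)c(F)c1` gives 1.5 nM in this assay.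

Compound 3 stands highest of the three numbers: its nearest neighbour is compound 1, with a 2.5-fold higher number from compound 1 to compound 3 (0.40 log units; beyond the scatter), and its furthest is compound 2, with a 5.0-fold higher number from compound 2 to compound 3 (0.70 log units; beyond the scatter). Compound 4 `CC(C(=O)NCc1ccc(C(F)(F)F)nc1/C=C/C1CCCCC1)c1ccc(NS(C)(=O)=O)c(F)c1` is the next step from compound 3. The change is a group of 8 heavy atoms (8 carbon; one six-membered non-aromatic ring of carbon only) in place of a group of 7 heavy atoms (7 carbon; 2 five-membered non-aromatic rings of carbon only), on an aromatic carbon, on an aromatic carbon of a six-membered aromatic ring with 1 nitrogen.

Going by the values given here, two measured steps bear on this. The step of a 5.0-fold higher number from compound 2 to compound 3 (0.70 log units; beyond the scatter) swapped a group of 8 heavy atoms with one six-membered non-aromatic ring for the two-ring group, and the number rose beyond the scatter. The step of a 2.5-fold higher number from compound 1 to compound 3 (0.40 log units; beyond the scatter) did the same from a chain and also rose. The entering 2-cyclohexylethenyl group of compound 4 again brings one six-membered non-aromatic ring and 8 heavy atoms, so the step to compound 4 is expected to run the other way, toward lower numbers, by a 3.0-fold lower number from compound 3 to compound 4 (0.48 log units; beyond the scatter). Compound 4 is therefore expected at about 0.5 nM, within 0.2 nM to 1.5 nM.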

Compound 4, inhibition constant: 0.7 nM
Beside the measured number, compound 4's estimate is 1.4-fold (0.15 log units) below it; low and high end bracket the measured number.
By their numbers in this assay, from the lowest: compounds 2, 1 and 4 (each within the scatter of the next, the first and the last beyond it); then compound 3.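

In this assay, the 2-cyclohexylethenyl group is the only one of the four substituents with a double bond outside the aromatic rings, and this aromatic carbon next to the ring nitrogen accepts it: the change gives a 2.1-fold lower number from compound 3 to compound 4 (0.33 log units; beyond the scatter), although a 2.3-fold higher number from compound 2 to compound 4 (0.37 log units; beyond the scatter) shows that it does not match the 4-ethylcyclohexyl group. Against the 3,3-dimethylbutyl group the result is a 1.2-fold higher number from compound 1 to compound 4 (0.07 log units; within the scatter), so those two groups cannot be told apart here. Nothing available accounts for these differences.

As far as these compounds go, what the saturated 2-cyclohexylethyl group would give at this position remains open, so the part played by the double bond cannot be separated from that of the cyclohexyl ring. Also open, from the compounds shown here alone, is how a ring containing an amine nitrogen or an ether oxygen would fare here.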